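From an acetoxy side chain to a hydroxy(phenyl)methyl group

This account rests on a few compounds, and the source may have more. Where it says the series, first, only, none or still open, it means among the compounds named here.

Three esters sharing one quinone core have been measured in a functional assay on DU-145 cells (Homo sapiens) for cytotoxicity, read by MTT assay; a higher number here means a weaker inhibitor, a lower number a stronger inhibitor. Compound 1 `CCCC(O)CC(=O)O[C@H](CC=C(C)C)C1=CC(=O)c2c(O)ccc(O)c2C1=O` reaches only the limit of the assay, giving > 100000 nM. Compound 2 `CC[C@](C)(O)CC(=O)O[C@H](CC=C(C)C)C1=CC(=O)c2c(O)ccc(O)c2C1=O` gives 20500 nM, and compound 3 `CCCCC(CC(=O)O[C@H](CC=C(C)C)C1=CC(=O)c2c(O)ccc(O)c2C1=O)OC(C)=O` gives 67700 nM, which is the highest of the two numbers that are not limits. The steps between them are an at least 4.8-fold lower number from compound 1 to compound 2 (0.68 log units; beyond the scatter), an at least 1.4-fold lower number from compound 1 to compound 3 (0.16 log units; that floor lies within the scatter) and a 3.3-fold higher number from compound 2 to compound 3 (0.52 log units; beyond the scatter); the first of these rests on (the limit of > 100000 nM in this assay, at which 1 of the 3 values shown sits).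

Compound 4 `CC(C)=CC[C@@H](OC(=O)CC(O)c1ccccc1)C1=CC(=O)c2c(O)ccc(O)c2C1=O` has not yet been measured. It differs from compound 3 in one place: hydroxy(phenyl)methyl in place of 1-acetoxypentyl on a saturated chain carbon bound to a carbonyl carbon. Among the compounds with values here, no measured step swaps an acetoxy for a hydroxyl on an aromatic-bearing carbon, so the closest guide is the contrast between compound 1, a secondary hydroxyl chain that sits at the limit, and compound 3, the acetoxy chain. That contrast lies within the scatter, and the tertiary hydroxyl of compound 2 points the other way. The change is therefore expected to bring a 1.4-fold lower number from compound 3 to compound 4 (0.13 log units; within the scatter), with no clear direction beyond the scatter. Compound 4 is expected to give about 50000 nM, between 10000 nM and 150000 nM.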

Compound 4, half-maximal inhibitory concentration: 17000 nM
The estimate for compound 4 lay 2.9-fold (0.47 log units) above the measured number, within the range that was stated.
By their numbers in this assay, from the lowest: compounds 4 and 2 (each within the scatter of the next); then compound 3. At a limit, above all of these: compound 1.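

In this assay, hydroxy(phenyl)methyl in place of 1-acetoxypentyl gives a 4.0-fold lower number from compound 3 to compound 4 (0.60 log units; beyond the scatter), while in place of 1-hydroxy-1-methylpropyl it gives a 1.2-fold lower number from compound 2 to compound 4 (0.08 log units; within the scatter), so on this saturated chain carbon bound to a carbonyl carbon, a group with an aromatic ring and a group without one can read alike. Phenyl in place of propyl gives an at least 5.8-fold lower number from compound 1 to compound 4 (0.76 log units; beyond the scatter), which shows that, with the hydroxyl kept in the side chain, the group carried alongside it on that carbon can move the number beyond the scatter. Compound 1 stands at a limit, so that step is a floor and not a measured size: the limit of > 100000 nM in this assay, at which 1 of the 4 values shown sits.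

The step from 1-acetoxypentyl to hydroxy(phenyl)methyl exchanges the acetoxy for a hydroxyl and the open chain for a phenyl ring at once, and the values shown do not separate these two parts. From the compounds shown here alone, how an acetoxy on the phenyl-bearing carbon, an amine in place of the hydroxyl, or a pyridine ring in place of the phenyl would read in this assay remains open.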